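This account rests on a few compounds, and the source may have more. Where it says the series, first, only, none or still open, it means among the compounds named here.

Three sulfonamides sharing one core have been measured so far. Compound 1 `O=S(=O)(Nc1ccccc1)c1ccc(Br)cc1` gives, in a functional assay on A549 cells (Homo sapiens) for inhibition (on this read-out lower numbers stand for stronger inhibition of growth and higher numbers for weaker inhibition of growth), a value of 30000 nM. Compound 2 `O=S(=O)(Nc1ccccc1)c1ccc(I)cc1` gives 23000 nM in this assay, and compound 3 `CC(C)(C)c1ccc(S(=O)(=O)Nc2ccccc2)cc1` gives 16000 nM. Compound 3 carries the lowest of the three numbers, but the gaps are small: the step of a 1.9-fold lower number from compound 1 to compound 3 (0.27 log units; within the scatter) and the step of a 1.4-fold lower number from compound 2 to compound 3 (0.16 log units; within the scatter) both lie within the scatter, as does the step of a 1.3-fold lower number from compound 1 to compound 2 (0.12 log units; within the scatter), so none of the three can be set apart from the others.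

The next compound, compound 4 `CC(C)(C)c1ccc(S(=O)(=O)Nc2cccc(O)c2)cc1`, differs from compound 3 by hydroxy in place of hydrogen on an aromatic carbon. Cut one bond further out, the difference reads phenyl to 3-hydroxyphenyl. None of the three measured steps bears on this change: each of them exchanged the bromo, iodo or tert-butyl group on the other ring, and none touched the ring that now receives the hydroxy group. Going by the values given here, there is therefore no measured step from which to expect a move in this assay beyond the scatter in either direction. Compound 4 is accordingly expected to give about 14000 nM, in the range 5000 nM to 40000 nM, an estimated step of a 1.1-fold lower number from compound 3 to compound 4 (0.06 log units; within the scatter) that stays within the scatter.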

Compound 4, concentration for 50% growth inhibition: 12000 nM
The estimate for compound 4 lay 1.2-fold (0.07 log units) above the measured number; measured number inside the range.
By their numbers in this assay, from the lowest: compounds 4, 3, 2 and 1 (each within the scatter of the next, the first and the last beyond it).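

The change from phenyl to 3-hydroxyphenyl is the first one shown on this ring, and in this assay it amounts to a 1.3-fold lower number from compound 3 to compound 4 (0.12 log units; within the scatter). Hydroxy in place of hydrogen at this aromatic carbon, with its one hydrogen-bond donor and one hydrogen-bond acceptor, therefore leaves the number within the scatter of that of the parent, so the change can be accepted here without a measurable gain or loss on this read-out. Nothing measured on these compounds speaks to why this is so.

Going by these compounds, it remains open whether an amine, a methoxy group or a carboxylic acid at the same place, or a hydroxy group elsewhere on this ring, would move the number beyond the scatter, and whether hydroxy would give a similar step with bromo or iodo in place of the tert-butyl group. It is also open whether any single change to the shared core can produce a step beyond the scatter, since each one-place step shown so far lies within it.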